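Replacing an aminophenyl with a dichlorophenyl on a chalcone-like core

A few compounds are considered here, and "the series" means these few. Any claim that something is new, unique, unknown or untested is made for them only; others in the source may bear on it.

Measured so far:
- compound 1, `COc1ccc(-c2cc(/C=C/C(=O)c3ccc(N)cc3)[nH]n2)cc1`: 76%
- compound 2, `COc1cc(-c2cc(/C=C/C(=O)c3ccc(N)cc3)[nH]n2)cc(OC)c1OC`: 85%

Both compounds were tested in a functional assay on SN12C cells (Homo sapiens) for cytotoxicity, read by sulforhodamine B assay, with a stated time of 48 h, tested at 1 uM; on this read-out higher numbers stand for a weaker effect at the one concentration tested and lower numbers for a stronger effect. Compound 2 gives 85%, and compound 1 gives 76%; the gap between them lies within the usual scatter of repeated measurements, so the two numbers cannot be told apart. Both compounds share the same core and the same 4-aminophenyl group on the carbonyl carbon; they differ only in the methoxy pattern on the other aromatic ring, and that difference leaves the read-out essentially unchanged.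

Compound 3, `COc1cc(-c2cc(/C=C/C(=O)c3ccc(Cl)c(Cl)c3)[nH]n2)cc(OC)c1OC`, keeps the trimethoxy side of compound 2 and alters the other end: 3,4-dichlorophenyl in place of 4-aminophenyl on a carbonyl carbon. Within the data shown here, no step between measured compounds tells how this position responds, so any expectation rests on the general picture of two compounds giving nearly the same read-out. The step is expected to be small, in either direction, and likely not beyond the scatter: a number 10 percentage points lower from compound 2 to compound 3 (within the scatter). Compound 3 is therefore expected to give about 75%, within a range from 50% to 98%.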

Compound 3, a percentage reported as activity, at one concentration (the size of the read-out at that concentration, not a potency): 91%
The estimate for compound 3 lay 16 percentage points below the measured number; measured number inside the range.
By their numbers in this assay, from the lowest: compounds 1, 2 and 3 (each within the scatter of the next, the first and the last beyond it).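

In this assay, among these compounds, the place on the carbonyl carbon can now be read for the first time: 3,4-dichlorophenyl in place of 4-aminophenyl gives a number 6 percentage points higher from compound 2 to compound 3 (within the scatter) and so leaves the read-out indistinguishable. This exchange is not a close one by the counts, since the entering group has 0 hydrogen-bond donors and 0 hydrogen-bond acceptors where the leaving group has 1 of each, and it also brings in two chlorine atoms; even so, this single pair shows no measurable response at this position. No measurement at hand explains this result, so it stands as an observation without a cause.

From the compounds shown here alone, whether a group of a different kind on this carbonyl carbon, such as a carboxylic acid, a morpholine or a longer alkyl chain in place of the aromatic ring, would shift the read-out beyond the scatter remains open. Also open, going by these compounds, is whether the same exchange would give the same outcome with the methoxy pattern of compound 1 on the other aromatic ring, or at concentrations other than the single one used here.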